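From a cyclohexyl amide to a piperidinyl urea

This account rests on a few compounds, and the source may have more. Where it says the series, first, only, none or still open, it means among the compounds named here.

Measured compounds:
compound 1 `CC1CCCC(C(=O)N2CC(c3nc(-c4cccc(Cl)c4)no3)C2)C1` — > 10000 nM
compound 2 `Cc1ccc(S(=O)(=O)N2CC(c3nc(-c4cccc(Cl)c4)no3)C2)cc1` — 920 nM

In an assay on HEK293 cells for negative allosteric modulation of metabotropic glutamate receptor 5 (Homo sapiens), read by FLIPR (on this read-out lower numbers stand for stronger inhibition and higher numbers for weaker inhibition), compound 1 gives > 10000 nM, which is a limit of the assay and not a measured number, as stated in the limit of > 10000 nM in this assay, at which 1 of the 2 values shown sits. In this assay compound 2 gives 920 nM. Going by the values given here, compound 2 differs from compound 1 in more than one place, so no single step between the two is described here, and only the two values themselves stand.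

Compound 3 `CC1CCN(C(=O)N2CC(c3nc(-c4cccc(Cl)c4)no3)C2)CC1` is not yet measured. It differs from compound 1 by 4-methylpiperidin-1-yl in place of 3-methylcyclohexyl on a carbonyl carbon. The counted difference shows that the group entering matches the group leaving in ring size and in the absence of hydrogen-bond donors and acceptors. Since compound 1 sits at the limit in this assay, the change from compound 1 to compound 3 is expected to bring no step beyond the usual scatter, so an at least 1.1-fold lower number from compound 1 to compound 3 (0.04 log units; that floor lies within the scatter) is the expected step. Compound 3 is therefore estimated at 9000 nM in this assay, with a range from 2500 nM to 30000 nM, and a fair chance that only a limit is reported again.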

Compound 3, half-maximal inhibitory concentration: > 10000 nM
Compound 3: a limit, no number; the forecaster's own chance of this, stated with the estimate: 55%; middle value at least 1.1-fold (0.04 log units) from the limit.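

In this assay compound 3 gives > 10000 nM, which is a limit of the assay and not a number. Compound 1 also stands at a limit, so no step can be read from compound 1 to compound 3: the limit of > 10000 nM in this assay, at which 2 of the 3 values shown sit. The compounds shown leave open how 4-methylpiperidin-1-yl and 3-methylcyclohexyl on the carbonyl carbon compare in strength of inhibition.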